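A few compounds are considered here, and "the series" means these few. Any claim that something is new, unique, unknown or untested is made for them only; others in the source may bear on it.

Measured so far, in a functional assay on HT-29 cells (Homo sapiens) for antiproliferative activity, read by MTT assay, with a stated time of 24 h; on this read-out lower numbers stand for stronger inhibition and higher numbers for weaker inhibition:
compound 1, `COc1ccc(C(=O)/C=C/c2ccc(-c3ccccc3)cc2)c2c1C=CC(C)(C)O2`, reported only as a limit: > 10000 nM
compound 2, `COc1ccc(C(=O)/C=C/c2ccc(C(F)(F)F)cc2)c2c1C=CC(C)(C)O2`, reported only as a limit: > 10000 nM
compound 3, `COc1ccc(C(=O)/C=C/c2ccccc2)c2c1C=CC(C)(C)O2`, reported only as a limit: > 10000 nM

Compound 3 stands at a limit of this assay, not at a number, and the two other values shown are limits too; all three sit at the same point, (the limit of > 10000 nM in this assay, at which 3 of the 3 values shown sit). The steps a step that the two limits leave unreadable from compound 1 to compound 2, a step that the two limits leave unreadable from compound 1 to compound 3 and a step that the two limits leave unreadable from compound 2 to compound 3 are consequently unreadable in size and direction: the changes at that aromatic carbon, from phenyl through trifluoromethyl to hydrogen, leave no measurable trace within the range of this assay.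

Compound 4, `COc1ccc(C(=O)/C=C/c2cccc(O)c2)c2c1C=CC(C)(C)O2`, differs from compound 3 by hydroxy in place of hydrogen on an aromatic carbon.

Among the measured compounds shown here, no measured step bears on a hydroxy entering, and no readable step of any kind exists in the set. The expectation for compound 4 therefore rests on the limit alone: a step that the limit leaves unreadable from compound 3 to compound 4 is expected, with no direction beyond the scatter claimed. Compound 4 is estimated at 15000 nM in this assay, within a range of 3000 nM to 60000 nM, most likely reported again only as a limit.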

Compound 4, half-maximal inhibitory concentration: > 10000 nM
Compound 4 was reported as a limit; the forecaster's own chance of this, stated with the estimate: 75%; the middle value does not contradict the limit.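

In this assay, among the compounds shown here, compound 4 gives > 10000 nM, which is a limit, so no step from compound 3 to compound 4 can be read: the limit of > 10000 nM in this assay, at which 4 of the 4 values shown sit. The compounds shown leave open whether any group on that aromatic ring gives a measurable value in this assay.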